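Methylsulfanyl for Methoxy on the Oxazole Series

The source may report more compounds than this note shows. Statements on the series, on what has been measured and on what is new or still open speak of the compounds shown alone.

Measured compounds:
- compound 1 `COc1cc(/C=C\c2cccc(OC)c2SC)cc(OC)c1OC`: 14500 nM
- compound 2 `COc1ccc(-c2ocnc2-c2cc(Br)c(OC)c(OC)c2)cc1OC`: 260 nM

In a functional assay on SK-OV-3 cells (Homo sapiens) for cytotoxicity, read by MTT assay, with a stated time of 48 h (on this read-out higher numbers stand for weaker inhibition and lower numbers for stronger inhibition), compound 2 gives 260 nM, the lowest of the two numbers shown; compound 1 gives 14500 nM, a number well beyond the scatter. Compound 3 `COc1ccc(-c2ocnc2-c2cc(Br)c(OC)c(OC)c2)cc1SC` is not yet measured. It differs from compound 2 in one place: methylsulfanyl in place of methoxy on an aromatic carbon. For the measured compounds named here, no measured pair shows this change, so its size is unknown. The step of a 1.2-fold higher number from compound 2 to compound 3 (0.06 log units; within the scatter) is expected to be small, in no firm direction. Compound 3 is estimated at 300 nM in this assay, within 100 nM to 1000 nM.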

Compound 3, half-maximal inhibitory concentration: 1160 nM
Beside the measured number, compound 3's estimate is 3.9-fold (0.59 log units) below it, and the stated range ends below it.
By their numbers in this assay, from the lowest: compound 2; then compound 3; then compound 1.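

In this assay, methylsulfanyl in place of methoxy, on an aromatic carbon ortho to a methoxy group and meta to a large group, gives a 4.5-fold higher number from compound 2 to compound 3 (0.65 log units; beyond the scatter). This first step at the position is modest but beyond the scatter, so the position does respond to this exchange, and methoxy gives the lower number of the two. Nothing shown gives a reason for this step. On these data alone, whether a hydroxy group, an ethoxy group or a fluorine atom here would match methoxy remains open. So does whether methylsulfanyl at another methoxy position would give a similar step.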